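Taking the nitro group off compound 2

The compounds below may be only part of what the source reports. "The series", "measured", "known", "first", "only" and "open" are said of these compounds alone.

In a functional assay, with a stated time of 10 min (a higher number here means a weaker inhibitor, a lower number a stronger inhibitor), compound 1 (`CN(C)c1ccc(/C=C/c2cc(=O)c(O)cn2C)cc1`) gives 2520 nM and compound 2 (`Cn1cc(O)c(=O)cc1/C=C/c1ccc([N+](=O)[O-])cc1`) gives 19200 nM as the higher of the two numbers, which makes compound 2 the weaker inhibitor of this pair. Compound 3 (`CCOc1ccc(/C=C/c2cc(=O)c(O)cn2C)cc1`) carries ethoxy in place of nitro on an aromatic carbon, para to a large group (ethoxy in place of nitro on an aromatic carbon). Going by the values given here, the one measured step that bears on this is nitro in place of dimethylamino on an aromatic carbon (a 7.6-fold higher number from compound 1 to compound 2 (0.88 log units; beyond the scatter)) , modest but beyond the scatter. Compound 3 also lacks the nitro, but ethoxy is not dimethylamino, so that step is only a rough guide. A lower number is expected in this assay, with an estimated step (a 3.8-fold lower number from compound 2 to compound 3 (0.58 log units; beyond the scatter)) somewhat smaller than the measured one. For compound 3 the estimate is 5000 nM, with an expected range from 1800 nM to 14000 nM.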

Compound 3, half-maximal inhibitory concentration: 4020 nM
For compound 3 the middle estimate is 1.2-fold (0.09 log units) above the measured one; the measured number falls inside the stated range.
By their numbers in this assay, from the lowest: compounds 1 and 3 (each within the scatter of the next); then compound 2.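

In this assay, replacing nitro with ethoxy on this aromatic carbon, para to a large group, gives a 4.8-fold lower number from compound 2 to compound 3 (0.68 log units; beyond the scatter), so the first measured step away from nitro is now joined by a second one with a different group. Ethoxy and dimethylamino cannot be told apart here, as the comparison gives a 1.6-fold higher number from compound 1 to compound 3 (0.20 log units; within the scatter), which leaves compound 2 as the one compound of the three that stands apart, while compound 1 and compound 3 sit together. Nothing at hand gives a reason for this difference.

As far as these compounds go, how a carboxylic acid, a primary amine or a longer alkoxy chain would read at this place remains open. So does whether a halogen such as chlorine would fall with nitro or with the other two groups.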